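The compounds below may be only part of what the source reports. "The series", "measured", "known", "first", "only" and "open" are said of these compounds alone.

In an ADME assay for permeability, using PAMPA, with a stated time of 10 h, tested at 100 ug/mL (a higher number here means that the compound crosses the layer faster, a lower number that the compound crosses the layer more slowly), compound 3 `Oc1c(Cl)cc(Cl)c2ccc(-c3cc4ccccc4[nH]3)nc12` gives 6.6 10^-6 cm/s. Compound 1 `Oc1cccc2ccc(-c3cc4ccccc4[nH]3)nc12` gives 8 10^-6 cm/s, within the scatter of compound 3. Compound 2 `Oc1ccc2[nH]c(-c3ccc4cccc(O)c4n3)cc2c1` gives 14.8 10^-6 cm/s, a number beyond the scatter above that of compound 3.

The next structure is compound 4 `Oc1c(Cl)cc(Cl)c2ccc(-c3cc4cc(F)ccc4[nH]3)nc12`, which carries fluoro in place of hydrogen on an aromatic carbon of compound 3: fluoro in place of hydrogen on an aromatic carbon.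

Going by the values given here, only one measured step bears on this change: a 1.9-fold higher number from compound 1 to compound 2 (0.27 log units; within the scatter). It also replaces hydrogen on an aromatic carbon, but the entering group is hydroxy, and the step stays within the scatter. Among the compounds with values here, no step with fluoro has been measured, so the evidence is indirect. No shift beyond the scatter is therefore expected in this assay, and no direction is firmly indicated.

The estimated step is a 1.1-fold higher number from compound 3 to compound 4 (0.06 log units; within the scatter), which is expected to remain within the scatter. For compound 4 the expected value is 7.5 10^-6 cm/s, with an estimated range from 3.8 10^-6 cm/s to 14 10^-6 cm/s.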

Compound 4, apparent permeability: 5.3 10^-6 cm/s
Compound 4: middle estimate off by 1.4-fold (0.15 log units), on the high side, within the range that was stated.
By their numbers in this assay, from the lowest: compounds 4, 3, 1 and 2 (each within the scatter of the next, the first and the last beyond it).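

Fluoro on this aromatic carbon, on a six-membered aromatic ring of carbon only, meta to a fused ring and para to a fused ring, now has a direct reading. In this assay, going by these compounds alone, the reading is a 1.2-fold lower number from compound 3 to compound 4 (0.10 log units; within the scatter) and it is the first measured step with fluoro. On the background of compound 3, this position therefore accepts this one-atom replacement of hydrogen without a shift beyond the scatter.

Open, going by these compounds, is whether methoxy, an amine or a carboxylic acid on the same carbon would also stay within the scatter, and whether fluoro reads the same way on the core of compound 1. Nothing measured here gives a reason for the result of this change.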